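The compounds below may be only part of what the source reports. "The series", "measured", "known", "first", "only" and "open" are said of these compounds alone.

The starting point is a small set of three compounds tested in a functional assay on HO8910 cells (Homo sapiens) for cytotoxicity, read by CCK-8 assay, with a stated time of 24 h; a higher number here means a weaker inhibitor, a lower number a stronger inhibitor. Compound 1 `C/C(=C\c1cc(C2=CCCCC2)co1)C(N)=O` reaches only the limit of the assay, giving > 50000 nM. Compound 2 `C/C(=C\c1cc(C2=CCCC2)co1)C(N)=O` likewise stops at a limit, giving > 50000 nM. Both of these sit at the limit of > 50000 nM in this assay, at which 2 of the 3 values shown sit. Compound 3 `C/C(=C\c1nc(-c2ccccc2)cs1)C(N)=O` is the only one of the three with a measured number: in this assay compound 3 gives 3780 nM, so it stands as the single real value among the three results shown.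

Compound 4 `C/C(=C\c1nc(-c2ccc(C)cc2)cs1)C(N)=O` has not yet been measured. It differs from compound 3 in one place: methyl in place of hydrogen on an aromatic carbon. Going by the values given here, no pair of measured compounds that differ in a single place is available, so there is no measured step to lean on. A change of this size is expected to move the number little, most likely within the usual scatter, in no definite direction. For compound 4 the expected step is a 1.3-fold lower number from compound 3 to compound 4 (0.10 log units; within the scatter). Compound 4 is therefore estimated at 3000 nM, within a range from 1200 nM to 9000 nM.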

Compound 4, half-maximal inhibitory concentration: > 50000 nM
Compound 4 ended at the assay's limit (the forecaster's own chance of this, stated with the estimate: 10%); middle value at least 16-fold (1.22 log units) away from the limit.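

Placing one methyl on an aromatic carbon of the six-membered aromatic ring of carbon only, para to a large group, gives an at least 13-fold higher number from compound 3 to compound 4 (1.12 log units; beyond the scatter) in this assay. On these data alone, compound 4 gives > 50000 nM, which is a limit of the assay and not a number, so the true size of the step remains unknown. This position therefore responds strongly to a change of a single heavy atom, and compound 3 alone keeps a measured value: the limit of > 50000 nM in this assay, at which 3 of the 4 values shown sit.

As far as these compounds go, whether fluorine, a hydroxyl or an amine at this same place would keep a measurable value remains open, as does the effect of a methyl elsewhere on this ring. With only one measured number, the compounds shown cannot explain why the value was lost.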